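The source may report more compounds than this note shows. Statements on the series, on what has been measured and on what is new or still open speak of the compounds shown alone.

Compound 1 `CCN(CC)S(=O)(=O)c1ccc(S(=O)(=O)N2CCC[C@@H](C(=O)N3CCS(=O)(=O)CC3)C2)cc1` gives > 10000 nM in a functional assay on MIA PaCa-2 cells (Homo sapiens) for inhibition, read by MTT assay, with a stated time of 3 days (on this read-out lower numbers stand for stronger inhibition and higher numbers for weaker inhibition), a limit of the assay rather than a number.
Compound 2 `O=C([C@@H]1CCCN(S(=O)(=O)c2ccc(S(=O)(=O)N3CC[C@@H](O)C3)cc2)C1)N1CCC(F)(F)CC1` gives > 3000 nM in this assay, likewise a limit.

On the numbers shown, compound 1 stands only at a limit, the one described by the limit of > 10000 nM in this assay, at which 1 of the 2 values shown sits, so no true value is known for it. Compound 3 `CCN(CC)S(=O)(=O)c1ccc(S(=O)(=O)N2CCC[C@@H](C(=O)N3CC[C@@H](OC)C3)C2)cc1` differs from compound 1 by 3-methoxypyrrolidin-1-yl in place of 1,1-dioxothiomorpholin-4-yl on a carbonyl carbon. No measured step joins the two, and compound 2 sits at its own limit (the limit of > 3000 nM in this assay, at which 1 of the 2 values shown sits), so nothing shown points to a gain. Compound 3 is therefore expected to stay at the limit, the expected step of a number no higher from compound 1 to compound 3 (the limit leaves the size open) being none beyond the scatter. Compound 3 is estimated at 10000 nM, in the range 3000 nM to 30000 nM.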

Compound 3, half-maximal inhibitory concentration: > 10000 nM
Compound 3: a limit, no number; the forecaster's own chance of this, stated with the estimate: 80%; the middle value lies on the limit itself.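

Compound 3 gives > 10000 nM in this assay, a limit and not a number. Compound 1 also stands at a limit, so no step can be read between compound 1 and compound 3. The compounds shown leave open the true value of each, and whether any group on this carbonyl carbon gives a measurable inhibition.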